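Chain extension at the ring nitrogen: compound 3 to compound 4

The compounds below may be only part of what the source reports. "The series", "measured", "known", "first", "only" and "open" are said of these compounds alone.

Compound 3 `CN(C)CCn1c(=O)c(=Cc2ccc(F)c(F)c2)s/c1=C1\C(=O)Nc2cc(F)ccc21` is measured in a functional assay on MDA-MB-231 cells (Homo sapiens) for inhibition, read by MTT assay, with a stated time of 72 h (a higher number here means a weaker inhibitor, a lower number a stronger inhibitor), where compound 3 gives 25000 nM. Of the two plain numbers in this assay, compound 3 holds the higher one; compound 1 `Cc1ccc2c(c1)/C(=c1/sc(=Cc3ccc(C=O)c(C=O)c3)c(=O)n1CCN(C)C)C(=O)N2` gives 8100 nM, and the gap between the two lies beyond the scatter. Compound 2 `CCN(CC)CCCn1c(=O)c(=Cc2cc(OC)c(OC)c(OC)c2)s/c1=C1\C(=O)Nc2ccc(C)cc21` returns in this assay only a limit, > 200000 nM, not a number. Going by the values given here, compound 2 carries the 3-(diethylamino)propyl chain that also appears in compound 4, but it differs in other places as well, so its value shows only that compound 2 sits at the limit of > 200000 nM in this assay, at which 1 of the 3 values shown sits.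

Compound 4 `CCN(CC)CCCn1c(=O)c(=Cc2ccc(F)c(F)c2)s/c1=C1\C(=O)Nc2cc(F)ccc21` differs from compound 3 in one place: (diethylamino)methyl in place of dimethylamino on a saturated chain carbon, two bonds along the chain from an aromatic nitrogen. Among the compounds with values here, no measured pair in this set isolates that change, so no measured step can be drawn. The expectation for the step from compound 3 to compound 4 in this assay is a weakening, a 2.0-fold higher number from compound 3 to compound 4 (0.30 log units; within the scatter), modest in size and possibly within the scatter, with a fair chance that this assay reports only a limit. Compound 4 is estimated at 50000 nM, with a range of 15000 nM to 200000 nM.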

Compound 4, half-maximal inhibitory concentration: 2900 nM
For compound 4 the middle estimate is 17-fold (1.24 log units) above the measured one; the whole stated range lies above it.
By their numbers in this assay, from the lowest: compound 4; then compound 1; then compound 3. At a limit, above all of these: compound 2.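

The chain on the ring nitrogen is a place where this assay responds to a single change: an 8.6-fold lower number from compound 3 to compound 4 (0.94 log units; beyond the scatter) when 3-(diethylamino)propyl replaces 2-(dimethylamino)ethyl and the rest of the structure stays the same. Going by these compounds alone, this is the only step in the set between compounds that differ in one place, so it gives the first direct reading of this position. No measured property bears on this step.

Still open, going by these compounds, is whether the longer chain or the ethyl groups on the amine account for the step, a question that a 3-(dimethylamino)propyl chain would separate, and whether a ring amine such as morpholine on the chain follows the same direction. Compound 2 gives > 200000 nM which is a limit and not a number, and it differs from compound 4 in more than one place, so no step can be read from it.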